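Bromophenyl to Dichlorophenyl: Expected Paw Edema Inhibition

This account rests on a few compounds, and the source may have more. Where it says the series, first, only, none or still open, it means among the compounds named here.

Compound 1 `COc1ccc(-c2cc3c(n2-c2ccc(O)c(C(=O)O)c2)CCCC3)cc1` and compound 2 `O=C(O)c1cc(-n2c(-c3ccc(Br)cc3)cc3c2CCCC3)ccc1O` share one core. In a functional assay on the whole organism (strain Wistar) for inhibition, with Rattus norvegicus as the target, read by paw edema, with stated times of 30 min and 3 h, at a dose of 200 mg/kg by the oral route (a lower number here means less inhibition, a higher number more inhibition at the dose given (going by the name of the read-out)), compound 1 gives 50%, and compound 2 gives 40%, the lowest of the two numbers shown, although the step of a number 10 percentage points lower from compound 1 to compound 2 (within the scatter) (bromo in place of methoxy on an aromatic carbon) lies within the scatter. Compound 3 `O=C(O)c1cc(-n2c(-c3ccc(Cl)c(Cl)c3)cc3c2CCCC3)ccc1O` differs from compound 2 in one place: 3,4-dichlorophenyl in place of 4-bromophenyl on an aromatic carbon. Among the measured compounds shown here, the only measured step bearing on this, the halogen-for-methoxy exchange, was small, so no step beyond the scatter is expected in this assay for this halogen-for-halogen exchange. Compound 3 is therefore expected to give 40%, between 25% and 55%. This estimate means a step of no change at the digits printed from compound 2 to compound 3 (within the scatter).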

Compound 3, a percentage reported as inhibition, in the whole organism at one dose (the size of the read-out at that dose, not a potency): 0%
Compound 3: middle estimate off by 40 percentage points, on the high side; measured number below the stated range.
By their numbers in this assay, from the lowest: compound 3; then compounds 2 and 1 (each within the scatter of the next).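

The aromatic carbon next to the ring nitrogen proves sensitive to the aryl group it carries in this assay: the 3,4-dichlorophenyl group gives a number 40 percentage points lower from compound 2 to compound 3 (beyond the scatter) and also a number 50 percentage points lower from compound 1 to compound 3 (beyond the scatter), both beyond the scatter. The earlier step from methoxy to bromo did not reveal this, so one halogen-bearing aryl group cannot stand in for another here. Nothing available explains this loss. The compounds shown leave open whether a single chlorine, as in 4-chlorophenyl, would retain inhibition, or whether the loss needs both chlorine atoms.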